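Halogen swap at the aryl ring of the thiazole acid series

The compounds below may be only part of what the source reports. "The series", "measured", "known", "first", "only" and "open" are said of these compounds alone.

Measured so far in an in vitro assay on COS-7 cells for displacement of a labelled ligand from prostaglandin D2 receptor 2 (Homo sapiens); on this read-out lower numbers stand for stronger inhibition and higher numbers for weaker inhibition:
compound 1 `O=C(O)Cc1sc(Nc2ccccc2)nc1-c1ccccc1` gives 350 nM
compound 2 `O=C(O)Cc1sc(Nc2ccccc2)nc1-c1ccc(F)cc1` gives 650 nM
compound 3 `COc1ccccc1Nc1nc(-c2ccc(F)cc2)c(CC(=O)O)s1` gives 1500 nM

Compound 3 holds the highest number of the three in this assay. The step nearest to it is a 2.3-fold higher number from compound 2 to compound 3 (0.36 log units; beyond the scatter), and the step one place further along the series is a 1.9-fold higher number from compound 1 to compound 2 (0.27 log units; within the scatter), so compound 3 sits beyond the scatter from both of the others.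

Compound 4 `COc1ccccc1Nc1nc(-c2ccc(Cl)cc2)c(CC(=O)O)s1` is not yet measured. It differs from compound 3 by chloro in place of fluoro on an aromatic carbon, the same difference read one bond further out being 4-fluorophenyl to 4-chlorophenyl. Within the data shown here, no measured pair in this assay exchanges one halogen for another. Among the measured compounds shown here, the only step touching this position is a 1.9-fold higher number from compound 1 to compound 2 (0.27 log units; within the scatter), a hydrogen-to-fluoro change that stayed within the scatter. On that basis a step of a 1.1-fold lower number from compound 3 to compound 4 (0.03 log units; within the scatter) is expected, with no clear direction. The estimate for compound 4 in this assay is 1400 nM, within 600 nM to 3200 nM.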

Compound 4, half-maximal inhibitory concentration: 450 nM
Beside the measured number, compound 4's estimate is 3.1-fold (0.49 log units) above it; measured number below the stated range.
By their numbers in this assay, from the lowest: compounds 1, 4 and 2 (each within the scatter of the next); then compound 3.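

In this assay, among these compounds, the 4-fluorophenyl to 4-chlorophenyl change gives a 3.3-fold lower number from compound 3 to compound 4 (0.52 log units; beyond the scatter) and is the first step at this position to lie beyond the scatter, whereas a 1.9-fold higher number from compound 1 to compound 2 (0.27 log units; within the scatter) stayed within it. The position, para to a large group, therefore responds to which halogen it carries, with chloro holding the lower number of the pair, at least where the methoxy group shared by compound 3 and compound 4 is present. Nothing available explains this response to the halogen.

From the compounds shown here alone, whether the same exchange holds on the core of compound 2, without the methoxy group, remains open. Also open, going by these compounds, is whether a bromo, methyl or trifluoromethyl group at this place would track chloro or fluoro.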